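This account rests on a few compounds, and the source may have more. Where it says the series, first, only, none or still open, it means among the compounds named here.

Measured compounds: compound 1 `CN(C)CCCNc1nc(-c2ccc(NC(=O)Nc3ccccc3Cl)cc2)nc2c(Cl)c(Cl)sc12` gives 820 nM in a functional assay on HT-29 cells (Homo sapiens) for cytotoxicity, read by MTT assay, with a stated time of 72 h; on this read-out lower numbers stand for stronger inhibition and higher numbers for weaker inhibition; compound 2 `CCN(CC)CCCNc1nc(-c2ccc(NC(=O)Nc3ccc(F)cc3)cc2)nc2c(Cl)c(Cl)sc12` gives 350 nM; compound 3 `CCN(CC)CCNc1nc(-c2ccc(NC(=O)Nc3ccc(F)cc3)cc2)nc2c(Cl)c(Cl)sc12` gives 650 nM.

Among these three numbers compound 3 stands second highest, and its gaps to compound 1 and to compound 2 both lie within the scatter. Compound 4 `CCN(CC)CCNc1nc(-c2ccc(NC(=O)Nc3ccccc3Cl)cc2)nc2c(Cl)c(Cl)sc12` differs from compound 3 by 2-chlorophenyl in place of 4-fluorophenyl on an amide-type nitrogen. Going by the values given here, no measured step covers this change alone: the single step of a 1.9-fold higher number from compound 2 to compound 3 (0.27 log units; within the scatter) concerns the chain, and compound 1 and compound 2 differ in two places, so their values only show a within-scatter gap between a 2-chlorophenyl and a 4-fluorophenyl bearer. Compound 4 is therefore expected to show a 1.2-fold higher number from compound 3 to compound 4 (0.06 log units; within the scatter), no step beyond the scatter. The estimate for compound 4 is 750 nM, expected between 300 nM and 1900 nM.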

Compound 4, half-maximal inhibitory concentration: 550 nM
For compound 4 the middle estimate is 1.4-fold (0.13 log units) above the measured one, and the stated range covers the measured number.
By their numbers in this assay, from the lowest: compounds 2, 4, 3 and 1 (each within the scatter of the next, the first and the last beyond it).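

In this assay the swap of 4-fluorophenyl for 2-chlorophenyl on the amide-type nitrogen can now be read alone, and it gives a 1.2-fold lower number from compound 3 to compound 4 (0.07 log units; within the scatter) with the rest of the structure unchanged. With 2-chlorophenyl held fixed, diethylamino in place of (dimethylamino)methyl on the chain gives a 1.5-fold lower number from compound 1 to compound 4 (0.17 log units; within the scatter) as its result, so neither change moves the number beyond the scatter. No measured evidence bears on these results. The compounds shown leave open how an unsubstituted phenyl, a methoxyphenyl or a pyridyl group on the same nitrogen would read in this assay as a test.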